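A few compounds are considered here, and "the series" means these few. Any claim that something is new, unique, unknown or untested is made for them only; others in the source may bear on it.

Compound 2, with the structure `OC(CCn1nc2c(Br)c(Br)c(Br)c(Br)c2n1)c1cccc(Cl)c1`, is measured in a functional assay on MCF7 cells (Homo sapiens) for antiproliferative activity, read by MTT assay, with a stated time of 24 h, tested at 50 uM (on this read-out lower numbers stand for a stronger effect and higher numbers for a weaker effect at the one concentration tested), at 28%. Among the three compounds measured, compound 2 stands second highest: compound 1, with the structure `OC(CCn1nc2c(Br)c(Br)c(Br)c(Br)c2n1)c1cccc(Br)c1`, gives 14%, and compound 3, with the structure `C[C@@H](O)CCn1nc2c(Br)c(Br)c(Br)c(Br)c2n1`, gives 102%. Among the measured compounds shown here, the one single-point step recorded is a number 14 percentage points higher from compound 1 to compound 2 (beyond the scatter). For the measured compounds named here, compound 3 carries no aryl group on the chain carbon bearing the oxygen, and its value is far higher than those of compound 1 and compound 2, but no step is recorded between it and either of them.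

Compound 4, with the structure `OC(CCn1nc2c(Br)c(Br)c(Br)c(Br)c2n1)c1ccc(Cl)cc1`, differs from compound 2 only in 4-chlorophenyl in place of 3-chlorophenyl on a saturated chain carbon bound to an oxygen on a saturated carbon and a saturated chain carbon. Going by the values given here, no measured step swaps one chlorophenyl for another, so the change from compound 2 to compound 4 is judged without a direct precedent. The halogen is kept and the aryl group is kept; only its substitution pattern changes. On that basis the expected step is a number 2 percentage points higher from compound 2 to compound 4 (within the scatter), that is, no change beyond the scatter. Compound 4 is therefore estimated at 30%, within the range 10% to 60%.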

Compound 4, a percentage reported as activity, at one concentration (the size of the read-out at that concentration, not a potency): 19%
For compound 4 the middle estimate is 11 percentage points above the measured one, and the stated range covers the measured number.
By their numbers in this assay, from the lowest: compounds 1, 4 and 2 (each within the scatter of the next, the first and the last beyond it); then compound 3.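

In this assay, 4-chlorophenyl in place of 3-chlorophenyl on the saturated chain carbon bound to an oxygen gives a number 9 percentage points lower from compound 2 to compound 4 (within the scatter), and 4-chlorophenyl in place of 3-bromophenyl at the same place gives a number 5 percentage points higher from compound 1 to compound 4 (within the scatter). Where the chlorine sits on the aryl group therefore makes no difference that this read-out can resolve, and compound 4 cannot be told apart from either compound 1 or compound 2, even though those two lie beyond the scatter of each other. No measurement on hand offers an explanation for these readings.

As far as these compounds go, it remains open how phenyl without a halogen, 2-chlorophenyl or 4-methoxyphenyl would read on that chain carbon, and what an amine in place of the hydroxyl would do there. From the compounds shown here alone, with a single concentration for each compound, the readings of compound 1, compound 2 and compound 4 show only the size of the effect at that concentration, and how the effect would stand at any other concentration remains open.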